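Swapping trifluoromethyl for hydroxy: what to expect for compound 4

This account rests on a few compounds, and the source may have more. Where it says the series, first, only, none or still open, it means among the compounds named here.

- compound 1 `COc1cc(NC(C)CCCNC(=O)NNC(=O)Nc2ccc(F)cc2)c2ncccc2c1` gives >= 250000 nM (a limit of the assay, not a number)
- compound 2 `COc1cc(NC(C)CCCNC(=O)Nc2ccc(F)cc2)c2ncccc2c1` gives 21000 nM
- compound 3 `COc1cc(NC(C)CCCNC(=O)Nc2ccc(C(F)(F)F)cc2)c2ncccc2c1` gives 8400 nM

These values come from a functional assay on MIA PaCa-2 cells (Homo sapiens) for inhibition, read by MTT assay, with a stated time of 72 h; on this read-out lower numbers stand for stronger inhibition and higher numbers for weaker inhibition. Among the two actual numbers, compound 3 has the lower one, at 8400 nM. The next step leads to compound 4 `COc1cc(NC(C)CCCNC(=O)Nc2ccc(O)cc2)c2ncccc2c1`, which has hydroxy in place of trifluoromethyl on an aromatic carbon.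

Going by the values given here, only one measured step changes a group at this place. It is a 2.5-fold lower number from compound 2 to compound 3 (0.40 log units; beyond the scatter), a modest change. The large steps, an at least 11-fold lower number from compound 1 to compound 2 (1.07 log units; beyond the scatter) and an at least 29-fold lower number from compound 1 to compound 3 (1.47 log units; beyond the scatter), alter a different part of the molecule, so they offer little guidance here. Neither fluoro nor trifluoromethyl resembles hydroxy closely, so the direction is uncertain. A modest rise in this assay seems most likely, to a number near that of compound 2 at 21000 nM.

The estimated step is a 2.6-fold higher number from compound 3 to compound 4 (0.42 log units; beyond the scatter).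

For compound 4 the expected value is 22000 nM, with an estimated range from 8000 nM to 70000 nM.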

Compound 4, half-maximal inhibitory concentration: 57000 nM
The estimate for compound 4 lay 2.6-fold (0.41 log units) below the measured number, within the range that was stated.
By their numbers in this assay, from the lowest: compound 3; then compound 2; then compound 4. At a limit, above all of these: compound 1.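

In this assay, this place on the aromatic ring, para to a large group, proves more sensitive than the fluoro and trifluoromethyl pair alone suggested: hydroxy brings a 6.8-fold higher number from compound 3 to compound 4 (0.83 log units; beyond the scatter) and a 2.7-fold higher number from compound 2 to compound 4 (0.43 log units; beyond the scatter), which puts the three groups in a clear order, with trifluoromethyl giving the lowest number, then fluoro, then hydroxy. Even so, the change elsewhere in the molecule still counts with hydroxy on the ring, with 4-hydroxyphenyl giving an at least 4.3-fold lower number from compound 1 to compound 4 (0.64 log units; beyond the scatter). Compound 1 stands at a limit of the assay, not a number, so that last step gives only a bound: the limit of >= 250000 nM in this assay, at which 1 of the 4 values shown sits.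

Three groups cannot show what sets this order. As far as these compounds go, it remains open where an amine, a carboxylic acid or a methoxy group at this place would fall, and whether the order holds with a longer chain.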